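Chloro for fluoro: an expected step in macrophage inhibition

A few compounds are considered here, and "the series" means these few. Any claim that something is new, unique, unknown or untested is made for them only; others in the source may bear on it.

In a functional assay on BMDM cells (Mus musculus, strain C57BL/6) for inhibition, with a stated time of 2 days (on this read-out higher numbers stand for weaker inhibition and lower numbers for stronger inhibition), compound 2 `Cc1csc(NC(=O)Cn2cc(-c3ccc(F)cc3)nn2)n1` gives 250 nM. Compound 1 `Cc1csc(NC(=O)Cn2cc(-c3ccc(Cl)cc3)nn2)n1` carries chloro in place of fluoro on an aromatic carbon; in this assay compound 1 gives 520 nM, and the result is a 2.1-fold higher number from compound 2 to compound 1 (0.32 log units; beyond the scatter). Compound 3 `O=C(Cn1cc(-c2ccc(F)cc2)nn1)Nc1nccs1` has a different core, namely (hydrogen in place of methyl on an aromatic carbon), and in this assay compound 3 gives 190 nM, a step of a 1.3-fold lower number from compound 2 to compound 3 (0.12 log units; within the scatter). Among the measured compounds shown here, compound 4 `O=C(Cn1cc(-c2ccc(Cl)cc2)nn1)Nc1nccs1` awaits measurement; it differs from compound 3 by chloro in place of fluoro on an aromatic carbon, the same change as the one between compound 2 and compound 1, since the surroundings of the changed carbon read identically in both cases. In this assay, for the measured compounds named here, compound 4 is expected to show a 2.1-fold higher number from compound 3 to compound 4 (0.32 log units; beyond the scatter), because a 2.1-fold higher number from compound 2 to compound 1 (0.32 log units; beyond the scatter) is the only measured example of this change and it raised the number modestly. The value of compound 4 is estimated at 400 nM, with a likely range from 200 nM to 800 nM.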

Compound 4, half-maximal inhibitory concentration: 1100 nM
Estimate against measurement, compound 4: 2.8-fold (0.44 log units) below; measured number outside the range, above it.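

In this assay, chloro in place of fluoro gives a 5.8-fold higher number from compound 3 to compound 4 (0.76 log units; beyond the scatter), so the direction of the earlier step carries over to the second core, but its size does not: the same change on two cores in this assay, a 2.1-fold higher number (0.32 log units; beyond the scatter) from compound 2 to compound 1 and a 5.8-fold higher number (0.76 log units; beyond the scatter) from compound 3 to compound 4, 2.8-fold (0.44 log units) apart, beyond the scatter of two such steps. Hydrogen in place of methyl also depends on its surroundings, giving a 2.1-fold higher number from compound 1 to compound 4 (0.33 log units; beyond the scatter) in the chloro pair, which does not match the step in the fluoro pair: the same change on two cores in this assay, a 1.3-fold lower number (0.12 log units; within the scatter) from compound 2 to compound 3 and a 2.1-fold higher number (0.33 log units; beyond the scatter) from compound 1 to compound 4, 2.8-fold (0.44 log units) apart, beyond the scatter of two such steps. The two changes therefore do not act independently in these four compounds, but this one comparison shows neither why nor how either change would behave on a further core.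

The compounds shown leave open whether bromo or methoxy in place of chloro would follow the same direction. They also leave open what an ethyl group or an amine in place of the methyl would do.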